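Piperazine Nitrogen Substituent and Liver Microsome Stability

A few compounds are considered here, and "the series" means these few. Any claim that something is new, unique, unknown or untested is made for them only; others in the source may bear on it.

Going by the values given here, compound 1 `CN(C[C@H]1Cc2c(cccc2N2CCN(Cc3ccccn3)CC2)CN1)[C@H]1CCCc2cccnc21` stands lowest of the two numbers so far: in an ADME assay on microsomes from liver (Homo sapiens) for metabolic stability, read by LC-MS, with a stated time of 10 min (a lower number here means that less of the compound is left, a higher number that more of the compound is left), compound 1 gives 4.2%. Compound 2 `CN(C[C@@H]1Cc2c(cccc2N2CCNCC2)CN1)[C@H]1CCCc2cccnc21` gives 94.2% in this assay, a value far above that of compound 1 and beyond the scatter. Compound 3 `CN(C[C@H]1Cc2c(cccc2N2CCN(c3cccc(C(F)(F)F)c3)CC2)CN1)[C@H]1CCCc2cccnc21` is not yet measured; it differs from compound 1 by 3-(trifluoromethyl)phenyl in place of (pyridin-2-yl)methyl on an amine nitrogen in a ring. Among the compounds with values here, no measured pair covers a change of this kind, so the step is open; a modest rise seems possible, but it may well stay within the scatter. Compound 3 is expected to give 10%, with a range from 1% to 35%. The expected step in this assay is a number 5.8 percentage points higher from compound 1 to compound 3 (within the scatter).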

Compound 3, percent of the compound remaining: 90.3%
Estimate against measurement, compound 3: 80.3 percentage points below, outside the stated range (above it).
By their numbers in this assay, from the lowest: compound 1; then compounds 3 and 2 (each within the scatter of the next).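

In this assay the step is a number 86.1 percentage points higher from compound 1 to compound 3 (beyond the scatter) with 3-(trifluoromethyl)phenyl in place of (pyridin-2-yl)methyl on the amine nitrogen. This first measured step at this position shows that exchanging this substituent alone, with the rest of the core of compound 1 kept, can move the percent remaining by a large amount. No measurement here bears on what lies behind this step. Still open, on these data alone, is whether the trifluoromethyl matters: a plain phenyl or a 3-chlorophenyl on this nitrogen would separate it from the ring. A benzyl would test the one-carbon link of the (pyridin-2-yl)methyl group.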